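Pyridyl isomer swap on the thiophene-borne aryl group

The compounds below may be only part of what the source reports. "The series", "measured", "known", "first", "only" and "open" are said of these compounds alone.

Compound 3 `O=C1[C@@H](NS(=O)(=O)c2ccc(-c3ccncc3)s2)CCN1CCNc1ccncc1` gives 41% in an assay on isolated protein for inhibition of coagulation factor X (Oryctolagus cuniculus), tested at 1 uM (on this read-out higher numbers stand for more inhibition at the one concentration tested (going by the name of the read-out) and lower numbers for less inhibition), the highest of the three numbers shown. Compound 1 `O=C1[C@@H](NS(=O)(=O)c2ccc(-c3ccon3)s2)CCN1CCNc1ccncc1` gives 22%, and compound 2 `O=C1[C@@H](NS(=O)(=O)c2ccc(-c3ccccn3)s2)CCN1Cc1cc2cc[nH]cc-2n1`, which carries a different group on the lactam nitrogen, gives 17%. For the measured compounds named here, the only single-change step recorded, a number 19 percentage points higher from compound 1 to compound 3 (beyond the scatter), concerns a different aryl group and so does not speak directly to compound 4 `O=C1[C@@H](NS(=O)(=O)c2ccc(-c3ccccn3)s2)CCN1CCNc1ccncc1`, which differs from compound 3 by pyridin-2-yl in place of pyridin-4-yl on an aromatic carbon. Going by the values given here, no measured pair isolates this exchange; compound 2 shares the entering group but not the rest of the molecule. Compound 4 is therefore expected at 30%, within 12% to 48%, meaning an estimated step of a number 11 percentage points lower from compound 3 to compound 4 (beyond the scatter) that may not exceed the scatter.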

Compound 4, a percentage reported as inhibition, at one concentration (the size of the read-out at that concentration, not a potency): 18%
Compound 4: middle estimate off by 12 percentage points, on the high side; the measured number falls inside the stated range.
By their numbers in this assay, from the lowest: compounds 2, 4 and 1 (each within the scatter of the next); then compound 3.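

In this assay, pyridin-2-yl in place of pyridin-4-yl next to the ring sulfur gives a number 23 percentage points lower from compound 3 to compound 4 (beyond the scatter) with the same atoms joined differently, so the isomer exchange alone moves the number beyond the scatter. Pyridin-2-yl in place of 1,2-oxazol-3-yl gives a number 4 percentage points lower from compound 1 to compound 4 (within the scatter) and does not separate these two groups. Exchanging the group on the saturated chain carbon bound to the amide-type ring nitrogen gives a number 1 percentage points higher from compound 2 to compound 4 (within the scatter) with pyridin-2-yl present.

No available evidence accounts for these results. On these data alone, how pyridin-3-yl at this position would compare with pyridin-4-yl remains open.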